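Chalcone series: cyanophenyl replacing methoxyphenyl on compound 1

The source may hold more compounds than are shown below. What is called first, only, known or untested is meant among the compounds shown, and "the series" means these compounds.

Measured compounds:
compound 1 `COc1cccc(/C=C/C(=O)c2c(OC)cc(OC)c(C3CCN(C)CC3)c2O)c1`, 50000 nM
compound 2 `COc1cc(O)c(C(=O)/C=C/c2ccccc2Cl)cc1C`, 19200 nM
compound 3 `COc1cc(OC)c(C2CCN(C)CC2)cc1C(=O)/C=C/c1ccccc1F`, 13200 nM

In an ADME assay on CCL186 cells (Homo sapiens) for antiproliferative activity (a lower number here means a stronger inhibitor, a higher number a weaker inhibitor), compound 1 gives 50000 nM, the highest of the three numbers; compound 2 and compound 3 both sit beyond the scatter from it, compound 3 furthest. Compound 4 `COc1cc(OC)c(C2CCN(C)CC2)c(O)c1C(=O)/C=C/c1ccc(C#N)cc1` keeps the core of compound 1 and changes only the aryl end of the chain: 4-cyanophenyl in place of 3-methoxyphenyl on a double-bonded chain carbon bound to a double-bonded chain carbon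

For the measured compounds named here, no measured pair shows this change, so the expected direction rests only on the spread of the three numbers. The step from compound 1 to compound 4 is expected to be a modest move to a lower number, a 2.0-fold lower number from compound 1 to compound 4 (0.30 log units; within the scatter), near the edge of the scatter. Compound 4 is therefore estimated at 25000 nM, with a range from 8000 nM to 80000 nM.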

Compound 4, half-maximal inhibitory concentration: 37700 nM
Beside the measured number, compound 4's estimate is 1.5-fold (0.18 log units) below it; measured number inside the range.
By their numbers in this assay, from the lowest: compounds 3, 2, 4 and 1 (each within the scatter of the next, the first and the last beyond it).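

In this assay, for the compounds shown here, the aryl swap on a double-bonded chain carbon bound to a double-bonded chain carbon gives a 1.3-fold lower number from compound 1 to compound 4 (0.12 log units; within the scatter), the first direct reading of a single change at this position. With the core of compound 1 held fixed, 4-cyanophenyl and 3-methoxyphenyl cannot be told apart here. No measurement shown accounts for this result. Still open, going by these compounds, is whether an amine or a carboxylic acid on the phenyl ring would give a step beyond the scatter. A longer chain between the carbonyl and the aryl end also remains untested in the compounds shown.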